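Working notes on a weak antiproliferative series

A few compounds are considered here, and "the series" means these few. Any claim that something is new, unique, unknown or untested is made for them only; others in the source may bear on it.

Measured so far:
- compound 1 `COc1cc(-c2nnc(SCC(=O)c3ccc(C(F)(F)F)cc3)n2N)cc(OC)c1OC`: > 100000 nM, a limit of the assay
- compound 2 `COc1cc(-c2nnc(SCC(=O)c3ccc(F)cc3)n2N)cc(OC)c1OC`: 90400 nM

In a functional assay on HepG2 cells (Homo sapiens) for antiproliferative activity, read by MTT assay, with a stated time of 48 h (a lower number here means a stronger inhibitor, a higher number a weaker inhibitor), compound 1 stands at the limit of > 100000 nM in this assay, at which 1 of the 2 values shown sits, so only a limit and no number is known for it. Compound 2 gives 90400 nM; the step of an at least 1.1-fold lower number from compound 1 to compound 2 (0.04 log units; that floor lies within the scatter) is all that is measured here.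

Compound 3 `COc1cc(-c2nnc(SCC(=O)NCc3ccc(Cl)cc3)n2N)cc(OC)c1OC` is not yet measured. Its change from compound 1: (4-chlorobenzyl)amino in place of 4-(trifluoromethyl)phenyl on a carbonyl carbon. Among the measured compounds shown here, no measured step bears on a change at the carbonyl carbon; the single measured step concerns a fluoro for trifluoromethyl exchange on the ring only. Compound 3 is therefore expected near compound 1, at an estimated 90000 nM (30000 nM to 300000 nM), an expected step of an at least 1.1-fold lower number from compound 1 to compound 3 (0.04 log units; that floor lies within the scatter), with a fair chance of a limit only.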

Compound 3, half-maximal inhibitory concentration: > 100000 nM
Compound 3 ended at the assay's limit; the forecaster's own chance of this, stated with the estimate: 50%; middle value at least 1.1-fold (0.04 log units) away from the limit.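

On the carbonyl carbon, (4-chlorobenzyl)amino brings no measurable gain: in this assay compound 3 gives > 100000 nM, a limit of the assay. Among the compounds shown here, the one readable step is an at least 1.1-fold higher number from compound 2 to compound 3 (0.04 log units; that floor lies within the scatter), and the step between the two limits cannot be read. A first change at the carbonyl carbon thus leaves the series at the weak end of the assay: the limit of > 100000 nM in this assay, at which 2 of the 3 values shown sit.

Still open, from the compounds shown here alone, is whether a carboxylic acid or a morpholine on the carbonyl carbon would give a number clear of this limit. Changes to the shared core also remain open.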